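The source may hold more compounds than are shown below. What is called first, only, known or untested is meant among the compounds shown, and "the series" means these compounds.

Numbers from an ADME assay on HEK293 cells (Homo sapiens) for antiproliferative activity, read by MTT assay, with a stated time of 24 h (on this read-out higher numbers stand for weaker inhibition and lower numbers for stronger inhibition), so far:
compound 1 `COc1ccc(-c2cc(/C=C/C(=O)c3ccc(C)cc3)nc3cc(-c4ccccc4)nn23)cc1OC`, 62600 nM
compound 2 `COc1ccc(C(=O)/C=C/c2cc(-c3ccc(OC)c(OC)c3)n3nc(-c4ccccc4)cc3n2)cc1`, 40000 nM

Among the compounds with values here, of the two numbers, compound 2 has the smaller one, but the single measured step, a 1.6-fold lower number from compound 1 to compound 2 (0.19 log units; within the scatter), lies within the scatter, so the two compounds are not separated on this read-out.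

Compound 3 `COc1ccc(C(=O)/C=C/c2cc(-c3ccc(OC)c(OC)c3)n3nc(-c4ccccc4)cc3n2)cc1OC` differs from compound 2 by methoxy in place of hydrogen on an aromatic carbon. Within the data shown here, no measured step makes this same change. Among the measured compounds shown here, the one step available, a 1.6-fold lower number from compound 1 to compound 2 (0.19 log units; within the scatter), touches the same ring but swaps methoxy for methyl rather than for hydrogen, and it stayed within the scatter. With only that to go on, the step from compound 2 to compound 3 is expected to be small, no change at the digits printed from compound 2 to compound 3 (within the scatter), with no direction claimed beyond the scatter. For compound 3 the estimate in this assay is 40000 nM, with a range from 15000 nM to 100000 nM.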

Compound 3, half-maximal inhibitory concentration: 32500 nM
Compound 3: middle estimate off by 1.2-fold (0.09 log units), on the high side; the range from low to high includes it.
By their numbers in this assay, from the lowest: compounds 3, 2 and 1 (each within the scatter of the next).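

On the carbonyl side, methoxy in place of hydrogen, ortho to a methoxy group, can now be read directly in this assay: a 1.2-fold lower number from compound 2 to compound 3 (0.09 log units; within the scatter), so 4-methoxyphenyl and 3,4-dimethoxyphenyl are not separated at this position. The larger swap of 3,4-dimethoxyphenyl for 4-methylphenyl on the carbonyl carbon gives a 1.9-fold lower number from compound 1 to compound 3 (0.28 log units; within the scatter), so all three groups tried here remain unseparated on this read-out. No measurement in hand offers an explanation for these results.

From the compounds shown here alone, whether an amine or a carboxylic acid on this ring would give a step beyond the scatter remains open. Going by these compounds, the phenyl and the 3,4-dimethoxyphenyl on the shared core are the same in all three compounds, so what changes at those two places would do is also open.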